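Removing the Bromo Group from Compound 3

The source may report more compounds than this note shows. Statements on the series, on what has been measured and on what is new or still open speak of the compounds shown alone.

Compound 1 `S=C(Nc1ccccc1)N1C/C(=C/c2ccccc2)S/C1=N\c1ccccc1`: > 100000 nM (a limit)
Compound 2 `COc1ccc(/C=C2\S/C(=N\c3ccc(C(C)(C)C)cc3)N(C)C2=O)cc1`: > 100000 nM (a limit)
Compound 3 `COc1ccc(/C=C2\S/C(=N\c3ccc(Br)cc3)N(C)C2=O)cc1`: 17000 nM

Among the measured compounds shown here, in a functional assay on HCT-116 cells (Homo sapiens) for antiproliferative activity, read by MTT assay, with a stated time of 72 h (on this read-out higher numbers stand for weaker inhibition and lower numbers for stronger inhibition), compound 3 gives 17000 nM, the only actual number among the three. The other two entries are limits and not numbers.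

Compound 4 `COc1ccc(/C=C2\S/C(=N\c3ccccc3)N(C)C2=O)cc1` carries one change from compound 3: hydrogen in place of bromo on an aromatic carbon. This puts hydrogen in place of bromo on an aromatic carbon, para to a large group.

For the measured compounds named here, one measured step bears on this place: an at least 5.8-fold lower number from compound 2 to compound 3 (0.76 log units; beyond the scatter). On these data alone, it lies beyond the scatter, but its true size stays open, and it does not test hydrogen directly.

On that step, a modest rise is expected, shown as a 2.4-fold higher number from compound 3 to compound 4 (0.37 log units; beyond the scatter). The estimate for compound 4 is 40000 nM, with an expected range of 12000 nM to 100000 nM.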

Compound 4, half-maximal inhibitory concentration: > 100000 nM
Compound 4 gave a limit, no number (the forecaster's own chance of this, stated with the estimate: 35%); at least 2.5-fold (0.39 log units) between middle value and limit.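

Removing the bromo, the change from 4-bromophenyl to phenyl, moves the result in this assay by an at least 5.8-fold higher number from compound 3 to compound 4 (0.76 log units; beyond the scatter). Hydrogen now joins tert-butyl in leaving no measured number, so among compounds 2, 3 and 4, which differ only at this place, bromo alone gives one. The step between compound 2 and compound 4 cannot be read, since both values are limits.

On these data alone, how large the loss truly is stays open, with the comparison resting on a limit: the limit of > 100000 nM in this assay, at which 3 of the 4 values shown sit. As far as these compounds go, whether chloro or an amine here would also give a measured number also stays open.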